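Trimming methoxy groups on a quinoxaline benzylamine series

This account rests on a few compounds, and the source may have more. Where it says the series, first, only, none or still open, it means among the compounds named here.

Compound 1, `Nc1cc(N)c2nc(-c3ccccc3)c(Oc3ccc(Cl)c(Cl)c3)nc2c1`, gives < 100000 nM in a functional assay on SF-268 cells (Homo sapiens) for inhibition, read by sulforhodamine B assay, with a stated time of 48 h; a higher number here means that more compound is tolerated, a lower number that less compound is tolerated; this is a limit of the assay.
Compound 2, `COc1cc(CNc2nc3cc(N)cc(N)c3nc2-c2ccccc2)cc(OC)c1OC`, gives 49000 nM in this assay.
Compound 3, `COc1ccc(CNc2nc3cc(N)cc(N)c3nc2-c2ccccc2)cc1OC`, gives < 100000 nM in this assay; this too is a limit.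

Compound 3 therefore stands only at a limit in this assay, and of the three values shown two sit at that limit (the limit of < 100000 nM in this assay, at which 2 of the 3 values shown sit). For the measured compounds named here, the one measured step that reaches compound 3, a step that the limit leaves unreadable from compound 2 to compound 3, cannot be read because of the limit. Compound 4, `COc1ccc(CNc2nc3cc(N)cc(N)c3nc2-c2ccccc2)cc1`, differs from compound 3 by hydrogen in place of methoxy on an aromatic carbon, the same kind of change as that from compound 2 to compound 3. There is thus no readable measured step of this kind, and the expectation for compound 4 rests only on the position of compound 3 at the limit and the value of compound 2. Compound 4 is expected to give 50000 nM in this assay, within 15000 nM to 100000 nM, which is an estimated step that the limit leaves unreadable from compound 3 to compound 4 from compound 3 to compound 4 and says no change beyond the scatter is expected.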

Compound 4, concentration lethal to 50% of the cells: 49000 nM
Estimate against measurement, compound 4: 1.0-fold (0.01 log units) above, within the range that was stated.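

No new step can be read from compound 3 to compound 4, because compound 3 stands only at a limit in this assay: the limit of < 100000 nM in this assay, at which 2 of the 4 values shown sit.

The compounds shown leave open where compound 3 lies relative to compound 2 and compound 4, and so whether either change of methoxy to hydrogen shifts the read-out at all.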